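A few compounds are considered here, and "the series" means these few. Any claim that something is new, unique, unknown or untested is made for them only; others in the source may bear on it.

In a functional assay on the whole organism with Rattus norvegicus as the target (a higher number here means that more compound is needed for the effect, a lower number that less compound is needed), two amides sharing one core have been measured. Compound 1 `CN(C)C(=O)/C=C1\CCc2ccc(F)cc21` gives 16 mg/kg, and compound 2 `O=C(/C=C1\CCc2ccc(F)cc21)NC1CCCC1` gives 14 mg/kg. Among the measured compounds shown here, the one measured step is a 1.1-fold lower number from compound 1 to compound 2 (0.06 log units; within the scatter), so compound 2 stands level with the only other measured compound.

Compound 3 `O=C(/C=C1\CCc2ccc(F)cc21)NCc1ccccc1` keeps the shared core and alters only the group on the amide nitrogen: benzyl in place of cyclopentyl on an amide-type nitrogen. In words, this is benzyl in place of cyclopentyl on an amide-type nitrogen. For the measured compounds named here, only the single measured step bears on this change, since it also concerns the amide, where cyclopentylamino took the place of dimethylamino on a carbonyl carbon. That step stayed within the scatter. Going by the values given here, it is thin evidence, however, and no compound with an aromatic ring in this group has yet been measured, so the data give no direction for the new change. No shift beyond the scatter is therefore expected, and the estimated step is a 1.1-fold lower number from compound 2 to compound 3 (0.03 log units; within the scatter). For compound 3 the expected value is 13 mg/kg, with an estimated range from 6 mg/kg to 30 mg/kg.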

Compound 3, dose for half-maximal effect: 16 mg/kg
Beside the measured number, compound 3's estimate is 1.2-fold (0.09 log units) below it, within the range that was stated.
By their numbers in this assay, from the lowest: compounds 2, 1 and 3 (each within the scatter of the next).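

In this assay the step reads a 1.1-fold higher number from compound 2 to compound 3 (0.06 log units; within the scatter) and so stays level, which shows that this amide-type nitrogen can carry a six-membered aromatic ring of carbon only in place of a five-membered non-aromatic one without leaving the scatter. Compound 3 is the first of the compounds shown with an aromatic ring in this group, and its benzyl group, at 7 heavy atoms against 5 for cyclopentyl, brings no shift that can be told apart from repeat measurements, so neither ring type nor this difference in size separates compound 2 from compound 3 here. Nothing measured here explains why the number holds level across this change.

As far as these compounds go, what remains open is whether any group on this nitrogen can move the number beyond the scatter, since cyclopentyl and benzyl both consist of carbon alone. A longer chain such as phenethyl, a benzyl carrying a carboxylic acid or an amine, or a replacement of the fluorine on the shared core would each test a different kind of change from those seen so far.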